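Ring-Enlarged Enol Side Chain in a Prostaglandin-Type Series

The source may report more compounds than this note shows. Statements on the series, on what has been measured and on what is new or still open speak of the compounds shown alone.

Three compounds of a shared core were examined in a functional assay on the whole organism (stomach) with Canis familiaris (Canis lupus familiaris) as the target; on this read-out lower numbers stand for an effect already at smaller amounts and higher numbers for an effect only at larger amounts of compound. Compound 1 `COC(=O)CC/C=C\CC[C@H]1C(=O)C[C@@H](O)[C@@H]1/C=C/C[C@@](C)(O)/C=C/C1=CCCC1` gives 0.00002 mg/kg. Compound 2 `COC(=O)CC/C=C\CC[C@H]1C(=O)C[C@@H](O)[C@@H]1/C=C/C[C@@](C)(O)C#CC1=CCCC1` gives 0.0028 mg/kg, and compound 3 `COC(=O)CC/C=C\CC[C@H]1C(=O)C[C@@H](O)[C@@H]1/C=C/C[C@@](C)(O)/C=C/C1CCCC1` gives 0.0003 mg/kg. Among the three, compound 3 stands second highest: its nearest neighbour is compound 2, with a 9.3-fold lower number from compound 2 to compound 3 (0.97 log units; beyond the scatter), while compound 1 lies further away, with a 15-fold higher number from compound 1 to compound 3 (1.18 log units; beyond the scatter).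

Compound 4 `COC(=O)CC/C=C\CC[C@H]1C(=O)C[C@@H](O)[C@@H]1/C=C/C[C@@](C)(O)/C=C/C1=CCCCC1` has not yet been measured in this assay. It differs from compound 3 at one place: cyclohex-1-en-1-yl in place of cyclopentyl on a double-bonded chain carbon bound to a double-bonded chain carbon. The change therefore both enlarges the ring by one carbon and puts a double bond back into it.

Among the compounds with values here, the step that bears most directly on this is the one from compound 1 to compound 3, where removing the ring double bond gave a 15-fold higher number from compound 1 to compound 3 (1.18 log units; beyond the scatter). The step from compound 1 to compound 2 concerns the linker rather than the ring and is less informative here. Because compound 1 gives 0.00002 mg/kg with an unsaturated ring while compound 3 with a saturated one gives 0.0003 mg/kg, compound 4 is expected to move back down, though the larger ring adds uncertainty, so a step of a 5.0-fold lower number from compound 3 to compound 4 (0.70 log units; beyond the scatter) is estimated. Compound 4 is thus expected to give about 0.00006 mg/kg, within a range of 0.00001 mg/kg to 0.0004 mg/kg.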

Compound 4, dose for half-maximal effect: 0.0003 mg/kg
The estimate for compound 4 lay 5.0-fold (0.70 log units) below the measured number, and the stated range covers the measured number.
By their numbers in this assay, from the lowest: compound 1; then compounds 3 and 4 (each within the scatter of the next); then compound 2.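

In this assay, cyclohex-1-en-1-yl in place of cyclopentyl on a double-bonded chain carbon bound to a double-bonded chain carbon gave no change at the digits printed from compound 3 to compound 4 (within the scatter), so at this place a ring double bond does not by itself carry over the low number of compound 1. Ring size could now be read with the ring double bond kept, and the single added ring carbon gave a 15-fold higher number from compound 1 to compound 4 (1.18 log units; beyond the scatter), a step of about the same size as the one seen earlier on losing the ring double bond, while the ethenyl linker with the larger ring still gave a 9.3-fold lower number from compound 2 to compound 4 (0.97 log units; beyond the scatter). Nothing available explains why the enlarged ring behaves in this way.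

Within the data shown here, with cyclohexyl absent from the series, the effects of ring size and the ring double bond cannot be fully separated, since the saturated five-membered ring and the unsaturated six-membered ring are the only pair that differ in both at once. On these data alone, how far this sensitivity extends also remains open, for example to cycloheptyl, to phenyl, or to a ring carrying an oxygen atom, such as tetrahydropyranyl.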